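Moving the acid onto a flexible benzyl arm

The compounds below may be only part of what the source reports. "The series", "measured", "known", "first", "only" and "open" are said of these compounds alone.

Compound 1 `CC(C)c1onc(-c2c(Cl)cccc2Cl)c1COc1ccc(NC(=O)c2ccc(C(=O)O)cc2)c(C(F)(F)F)n1`, compound 2 `CC(C)c1onc(-c2c(Cl)cccc2Cl)c1COc1ccc(N(C)C(=O)c2cccc(C(=O)O)c2)c(C(F)(F)F)n1` and compound 3 `Cc1cc(C(F)(F)F)cc(OCc2c(-c3c(Cl)cccc3Cl)noc2C(C)C)n1` share one core. In a functional assay on HEK293 cells for agonist activity at Bile acid receptor (Homo sapiens) (on this read-out lower numbers stand for an effect already at smaller amounts and higher numbers for an effect only at larger amounts of compound), compound 1 gives 474 nM and compound 2 gives 571 nM, the two within the usual scatter of each other, so compound 2 stands highest of the two numbers only nominally. Compound 3 is reported as "not active" (no number reported) in this assay, with no number. Compound 4 `CC(C)c1onc(-c2c(Cl)cccc2Cl)c1COc1ccc(N(C)Cc2ccc(OCC(=O)O)cc2)c(C(F)(F)F)n1` differs from compound 2 in one place: 4-(carboxymethoxy)benzyl in place of (3-carboxyphenyl)carbonyl on a nitrogen on an aromatic ring. Among the compounds with values here, no measured pair shows this change, so the size of the step is uncertain; a modest weakening beyond the scatter is expected, a 2.6-fold higher number from compound 2 to compound 4 (0.42 log units; beyond the scatter). Compound 4 is therefore estimated at 1500 nM, with a range from 300 nM to 8000 nM in this assay.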

Compound 4, half-maximal effective concentration: 214 nM
Beside the measured number, compound 4's estimate is 7.0-fold (0.85 log units) above it; the whole stated range lies above it.
By their numbers in this assay, from the lowest: compound 4; then compounds 1 and 2 (each within the scatter of the next).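

Swapping (3-carboxyphenyl)carbonyl for 4-(carboxymethoxy)benzyl on this nitrogen gives a 2.7-fold lower number from compound 2 to compound 4 (0.43 log units; beyond the scatter), so the carbonyl attached to the nitrogen is not required at this position, and a saturated chain carbon can take its place. No measurement at hand explains the gain. The step changes the linking atom and the arm carrying the acid together, so the compounds shown cannot say which of the two matters. As far as these compounds go, whether an amine could replace the carboxylic acid, or a longer chain could carry it, stays open.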